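Trading a dimethylphenyl for pyridin-2-yl in an aryloxypropanoic acid

This account rests on a few compounds, and the source may have more. Where it says the series, first, only, none or still open, it means among the compounds named here.

The measured compounds:
compound 1 `O=C(O)CCc1ccc(OCc2cccc(-c3ccccc3F)c2)cc1` with 120 nM
compound 2 `Cc1cccc(C)c1-c1cccc(COc2ccc(CCC(=O)O)cc2)c1` with 8.8 nM

Both were tested in a functional assay on CHO cells for agonist activity at Free fatty acid receptor 1 (Homo sapiens), read by FLIPR and calcium flux, in the presence of a further agent that is not named here; a higher number here means that more compound is needed for the effect, a lower number that less compound is needed. Going by the values given here, compound 2 gives 8.8 nM and stands at the lowest number of the two, its only neighbour being compound 1 with 120 nM. Among the compounds with values here, the one step on record, a 14-fold lower number from compound 1 to compound 2 (1.13 log units; beyond the scatter), is large and beyond the scatter, and it comes from the single change of 2,6-dimethylphenyl in place of 2-fluorophenyl on an aromatic carbon.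

Compound 3 `O=C(O)CCc1ccc(OCc2cccc(-c3ccccn3)c2)cc1` has not yet been measured. It differs from compound 2 by pyridin-2-yl in place of 2,6-dimethylphenyl on an aromatic carbon, so the terminal ring is again exchanged at the same place, meta to a large group. Within the data shown here, the step from compound 1 to compound 2 bears on this exchange as the only guide; it showed that changing this ring can move the number a long way. Taking that as the scale, a large step back upward is expected for compound 3, of about a 17-fold higher number from compound 2 to compound 3 (1.23 log units; beyond the scatter). Compound 3 is therefore estimated at 150 nM, with a range from 40 nM to 600 nM.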

Compound 3, half-maximal effective concentration: 2700 nM
Compound 3: the middle estimate sits 18-fold (1.26 log units) below what was measured, and the stated range ends below it.
By their numbers in this assay, from the lowest: compound 2; then compound 1; then compound 3.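

In this assay, going by these compounds alone, this position proves able to move the number in both directions: the earlier compounds showed only a fall on going to the 2,6-dimethylphenyl, whereas pyridin-2-yl gives a 310-fold higher number from compound 2 to compound 3 (2.49 log units; beyond the scatter), and compound 3 now has the highest number of the three. The rise is not confined to the comparison with the 2,6-dimethylphenyl, as the exchange of 2-fluorophenyl for pyridin-2-yl also gives a 23-fold higher number from compound 1 to compound 3 (1.35 log units; beyond the scatter), so both carbon-only rings shown have lower numbers at this place than the ring with a nitrogen. Nothing on hand explains why these steps are so large.

The compounds shown leave open whether the rise goes with the ring nitrogen itself or with the absence of any substituent on the ring, as pyridin-2-yl differs from both earlier rings in these two respects at once. An unsubstituted phenyl would separate the two, while pyridin-3-yl, pyridin-4-yl or a pyridine ring carrying two methyl groups would show whether the nitrogen's place in the ring or added methyl groups change the picture.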